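Swapping benzyl for phenyl and cell tolerance

The source may hold more compounds than are shown below. What is called first, only, known or untested is meant among the compounds shown, and "the series" means these compounds.

Four compounds with a shared core are compared in an ADME assay on HEL cells (Homo sapiens) for cytotoxicity, with a stated time of 3 days; a higher number here means that more compound is tolerated, a lower number that less compound is tolerated. Compound 1 `C=Cc1ccc(-c2cc(C)c3ncc(CSCCc4ccccc4)n3c2)cc1` gives 20 ug/mL. Compound 2 `C=Cc1ccc(-c2cc(C)c3ncc(CSCc4ccccc4)n3c2)cc1` gives >= 100 ug/mL, which is a limit of this assay rather than a number. The change from compound 1 to compound 2 is phenyl in place of benzyl on a saturated chain carbon bound to a sulfur, and it brings an at least 5.0-fold higher number from compound 1 to compound 2 (0.69 log units; beyond the scatter); the step can only be given as a lower bound because compound 2 sits at the limit of >= 100 ug/mL in this assay, at which 1 of the 3 values shown sits.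

Compound 3 `Cc1cc(N2CCCC2)c2ncc(CSCCc3ccccc3)n2c1` has a different core from compound 1, and the difference between the two cores is not broken down here. In this assay compound 3 gives > 100 ug/mL, which is a limit of the assay and not a number, matching (the limit of > 100 ug/mL in this assay, at which 1 of the 3 values shown sits).

Compound 4 `Cc1cc(N2CCCC2)c2ncc(CSCc3ccccc3)n2c1` has not yet been measured. It differs from compound 3 by phenyl in place of benzyl on a saturated chain carbon bound to a sulfur, the same change as that from compound 1 to compound 2. That earlier change moved a compound that was tolerated at a measurable concentration up to the limit of the assay. Compound 3 already stands at the limit, so no move upward can be seen. For compound 4 the expected step is a step that the limit leaves unreadable from compound 3 to compound 4, resting on compound 3 at > 100 ug/mL and on the direction of the earlier step. Compound 4 is therefore estimated at 150 ug/mL, most likely reported as a limit, with a plausible range from 80 ug/mL to 300 ug/mL.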

Compound 4, minimum cytotoxic concentration: >= 20 ug/mL
Compound 4: a limit, no number; the forecaster's own chance of this, stated with the estimate: 85%; the middle value lies beyond the limit too.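

In this assay compound 4 gives >= 20 ug/mL as a limit of the assay, not a number. Compound 3 gives > 100 ug/mL as a limit too, so no step can be read between compound 3 and compound 4. The compounds shown leave open how much of compound 3 and compound 4 is actually tolerated, and whether phenyl in place of benzyl changes that for this pair.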